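A few compounds are considered here, and "the series" means these few. Any claim that something is new, unique, unknown or untested is made for them only; others in the source may bear on it.

Of the compounds shown here, two on a shared core have numbers so far, compound 1 (`CO[C@@H]1[C@H]2OC(=O)C[C@H]2O[C@@H]1[C@H](O)c1ccccc1`) and compound 2 (`CO[C@@H]1[C@H]2OC(=O)C[C@H]2O[C@@H]1[C@@H](OC)c1ccccc1`). In a functional assay on Raji cells (Homo sapiens) for inhibition, read by MTT assay, with a stated time of 72 h (on this read-out higher numbers stand for weaker inhibition and lower numbers for stronger inhibition), compound 1 gives 8690 nM and compound 2 gives 10500 nM, and these two values lie within the usual scatter of each other, so the numbers do not set compound 2 apart from compound 1. Compound 3 (`CO[C@@H]1[C@H]2OC(=O)C[C@H]2O[C@@H]1[C@H](OC)c1ccccc1`) differs from compound 2 as follows: the two compounds have the same atoms and bonds and differ only in configuration as drawn: 1 of 5 stereo elements differ; a stereocentre at a saturated chain carbon is drawn S in compound 2 and R in compound 3 and a stereocentre at a saturated chain carbon is drawn S in compound 2 and R in compound 3. Within the data shown here, no measured pair isolates such a change, so the data give no direct guide to its size or direction. In this assay the change a 1.2-fold lower number from compound 2 to compound 3 (0.07 log units; within the scatter) is expected to stay within the scatter, with no firm direction. For compound 3 the estimated value is 9000 nM with an expected range from 3500 nM to 22000 nM at its upper end.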

Compound 3, half-maximal inhibitory concentration: 12400 nM
The estimate for compound 3 lay 1.4-fold (0.14 log units) below the measured number, within the range that was stated.
By their numbers in this assay, from the lowest: compounds 1, 2 and 3 (each within the scatter of the next).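

In this assay, among these compounds, the step of a 1.2-fold higher number from compound 2 to compound 3 (0.07 log units; within the scatter) is the first to isolate the configuration at this saturated chain carbon, and it shows that drawing the carbon as S or as R leaves the two numbers within the scatter of each other. The step of a 1.4-fold higher number from compound 1 to compound 3 (0.15 log units; within the scatter) adds a second reading at the same position, where methyl in place of hydrogen on the oxygen also stays within the scatter, with the methyl ether at this carbon now seen in both configurations. The first of these readings concerns the stereocentre alone, with nothing else altered: the fact that compounds 2 and 3 differ only in the configuration as drawn.

The compounds shown leave open whether a larger group on this oxygen, such as a benzyl ether or an acetate ester, would give a step beyond the scatter. They also leave open whether an amine at this carbon would do so, and whether the configuration would then count for more.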